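Compound 3 and its fluoro analogue

The source may hold more compounds than are shown below. What is called first, only, known or untested is meant among the compounds shown, and "the series" means these compounds.

For the measured compounds named here, in a functional assay on KG-1 cells (Homo sapiens) for cytotoxicity, read by luminescence and CellTiter-Glo, with a stated time of 3 days (a lower number here means a stronger inhibitor, a higher number a weaker inhibitor), compound 3 (`N#Cc1ccc(NC(=O)c2ccccc2O)cc1`) gives 5370 nM as the highest number of the three measured so far. Compound 1 (`N#Cc1ccc(NC(=O)c2ccc(Cl)cc2O)cc1`) gives 1920 nM and compound 2 (`Cc1ccc(C(=O)Nc2ccc(C#N)cc2)c(O)c1`) gives 2560 nM in the same read-out. Compound 4 (`N#Cc1ccc(NC(=O)c2ccc(F)cc2O)cc1`), not yet measured, differs from compound 3 by fluoro in place of hydrogen on an aromatic carbon in a single place, fluoro in place of hydrogen on an aromatic carbon. Going by the values given here, two measured steps bear on this change: a 2.8-fold higher number from compound 1 to compound 3 (0.45 log units; beyond the scatter) with hydrogen replacing chloro, and a 2.1-fold higher number from compound 2 to compound 3 (0.32 log units; beyond the scatter) with hydrogen replacing methyl. Chloro and methyl are set apart only by a 1.3-fold higher number from compound 1 to compound 2 (0.12 log units; within the scatter) in these data. Among the compounds with values here, no fluoro compound has been measured, so these steps offer only a rough guide. In this assay a partial reversal of them is expected, towards a lower number, and the step may end near the edge of the scatter. The estimated step is (a 1.9-fold lower number from compound 3 to compound 4 (0.27 log units; within the scatter)) in that direction. For compound 4 the estimate is 2900 nM with an expected range from 1400 nM to 5800 nM in this measurement.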

Compound 4, half-maximal inhibitory concentration: 3150 nM
Beside the measured number, compound 4's estimate is 1.1-fold (0.04 log units) below it; the measured number falls inside the stated range.
By their numbers in this assay, from the lowest: compounds 1, 2, 4 and 3 (each within the scatter of the next, the first and the last beyond it).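

In this assay, for the compounds shown here, fluoro is the first group at this place, meta to a hydroxy group and para to a large group, whose step from hydrogen stays within the scatter: a 1.7-fold lower number from compound 3 to compound 4 (0.23 log units; within the scatter) stands against the chloro and methyl steps from hydrogen, which lay beyond it. Fluoro also stays within the scatter of both those groups, with a 1.2-fold higher number from compound 2 to compound 4 (0.09 log units; within the scatter) and a 1.6-fold higher number from compound 1 to compound 4 (0.22 log units; within the scatter) as its steps. Compound 4 therefore cannot be told apart from compound 1, compound 2 or compound 3, although compound 3 lies beyond the scatter of the other two.

Going by these compounds, whether an amine or a methoxy group at this place would reach beyond the range of these four numbers remains open. No evidence shown gives a reason for the small differences among these four compounds.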